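Glutamate side chain of compound 1 replaced by serine

The source may hold more compounds than are shown below. What is called first, only, known or untested is meant among the compounds shown, and "the series" means these compounds.

Measured compounds in a functional assay on the whole organism (Tail, strain ICR) with Mus musculus as the target, in the tail flick test, with a stated time of 90 min, at a dose of 25 umol/kg by the oral route; a higher number here means a stronger effect of the compound at the dose given, a lower number a weaker effect:
- compound 1, `O=C(CN(c1nc(Cl)nc2[nH]cnc12)C1CC1)N[C@@H](CCC(=O)OCc1ccccc1)C(=O)OCc1ccccc1`, with compound 1 giving 50%
- compound 2, `CC(C)(C)OC(=O)NCCCC[C@H](NC(=O)CN(c1ncnc2c1ncn2C1CCCCO1)C1CC1)C(=O)OCc1ccccc1`, with compound 2 giving 32.9%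
- compound 3, `CC[C@H](C)[C@H](NC(=O)CN(c1nc(Cl)nc2[nH]cnc12)C1CC1)C(=O)O`, with compound 3 giving 27.4%

Compound 1 holds the highest of the three numbers in this assay. The nearest of the others is compound 2, whose number lies below that of compound 1 by more than the usual scatter, and compound 3 lies further below still, also beyond the scatter. Compounds 2 and 3 themselves sit within the scatter of each other, so no order is read between them.

The unmeasured compound 4, `O=C(CN(c1nc(Cl)nc2[nH]cnc12)C1CC1)N[C@@H](CO)C(=O)OCc1ccccc1`, keeps the core and the benzyl ester of compound 1 and changes one place on the chain:

hydroxy in place of (benzyloxycarbonyl)methyl on a saturated chain carbon, two bonds along the chain from an amide-type nitrogen and a carbonyl carbon

Going by the values given here, no pair of measured compounds shows exactly this change, so its size is not fixed by the data. Because compound 1 gives 50% and the shorter side chain of compound 3 goes with 27.4%, a downward step is expected, and the step from compound 1 to compound 4 is estimated as a number 12 percentage points lower from compound 1 to compound 4 (beyond the scatter), near the edge of the scatter rather than far beyond it. Compound 4 is therefore expected to give about 38%, within a range from 20% to 56%.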

Compound 4, a percentage reported as activity, at one dose (the size of the read-out at that dose, not a potency): 34.5%
For compound 4 the middle estimate is 3.5 percentage points above the measured one, within the range that was stated.
By their numbers in this assay, from the lowest: compounds 3, 2 and 4 (each within the scatter of the next); then compound 1.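

In this assay, hydroxy in place of (benzyloxycarbonyl)methyl on a saturated chain carbon, two bonds along the chain from an amide-type nitrogen and a carbonyl carbon, gives a number 15.5 percentage points lower from compound 1 to compound 4 (beyond the scatter). This first one-place step in the series shows that the read-out responds to this position, while the loss of the group with its six-membered aromatic ring still leaves compound 4 at 34.5%. No measurement at hand accounts for the step.

The step changes chain length, removes the benzyl ester of the side chain and introduces hydroxy all at once, and the compounds shown do not separate these parts. Also open, on these data alone, is how a carboxylic acid, an amine or a longer chain ending in hydroxy at the same place would read in this assay.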